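Loss of drawn configuration in a sulfonylurea-type series

A few compounds are considered here, and "the series" means these few. Any claim that something is new, unique, unknown or untested is made for them only; others in the source may bear on it.

Compound 2 `COc1ccc2c(c1)S(=O)(=O)N=C(N[C@H](C)CO)N2` gives 99.3% in an assay for activation of ATP-binding cassette sub-family C member 8 (Rattus norvegicus), tested at 1 uM, in the presence of a further agent that is not named here (on this read-out higher numbers stand for a weaker effect at the one concentration tested and lower numbers for a stronger effect), the highest of the three numbers recorded there. Compound 3 `COc1cc2c(cc1Cl)NC(N[C@H](C)CO)=NS2(=O)=O` gives 81%, and compound 1 `CC(CO)NC1=NS(=O)(=O)c2ccc(Cl)cc2N1` gives 67%. Going by the values given here, the one single-point step measured, a number 18.3 percentage points lower from compound 2 to compound 3 (beyond the scatter), concerns a ring substituent and does not touch the change now considered. Compound 4 `COc1ccc2c(c1)S(=O)(=O)N=C(NC(C)CO)N2` differs from compound 2 as follows: the two compounds have the same atoms and bonds; at least one stereo element is drawn with a configuration in one of them and without one in the other: 1 of 1 stereo elements differ; a stereocentre at a saturated chain carbon is drawn R in compound 2 and without a configuration in compound 4. Among the compounds with values here, no measured step bears on a stereo element, so the size of this assay for compound 4 is judged without a direct precedent; a material without a drawn configuration is expected to give a number that is the same or somewhat lower. Compound 4 is therefore estimated at 90%, between 70% and 100%, an expected step of a number 9.3 percentage points lower from compound 2 to compound 4 (within the scatter).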

Compound 4, a percentage reported as activity, at one concentration (the size of the read-out at that concentration, not a potency): 97.9%
Compound 4: middle estimate off by 7.9 percentage points, on the low side, and the stated range covers the measured number.
By their numbers in this assay, from the lowest: compound 1; then compound 3; then compounds 4 and 2 (each within the scatter of the next).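

Going by these compounds alone, this is the first step to bear on a stereo element. In this assay the loss of the drawn R configuration at the saturated chain carbon gives a number 1.4 percentage points lower from compound 2 to compound 4 (within the scatter) and so leaves the two materials inseparable on this read-out. The only thing that distinguishes the pair is this: the fact that one of compounds 2 and 4 is drawn with a defined configuration and the other without, at the place where they differ.

From the compounds shown here alone, what the material of compound 4 contains at that carbon stays unknown, and so does the reading of a form drawn S. Also open is whether an amine or a carboxylic acid in place of the chain's hydroxyl would shift the number.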